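Swapping a Sulfur-Bearing Group for 4-Ethylpiperazin-1-yl

The source may hold more compounds than are shown below. What is called first, only, known or untested is meant among the compounds shown, and "the series" means these compounds.

Within the data shown here, in a functional assay on MGC-803 cells (Homo sapiens) for inhibition, read by CCK-8 assay, with a stated time of 48 h (on this read-out higher numbers stand for weaker inhibition and lower numbers for stronger inhibition), compound 1 `COc1ccc(CN(C(=O)CSC(=S)N2CCN(C)CC2)c2cc(OC)c(OC)c(OC)c2)cc1` gives 1280 nM, the lower of the two numbers measured so far. Compound 2 `COc1ccc(CN(C(=O)CSC(=S)N2CCCc3cc(OC)ccc32)c2cc(OC)c(OC)c(OC)c2)cc1` gives 8210 nM. Compound 3 `CCN1CCN(CC(=O)N(Cc2ccc(OC)cc2)c2cc(OC)c(OC)c(OC)c2)CC1` keeps the core of compound 1 but carries one structural change: a group of 8 heavy atoms (6 carbon, 2 nitrogen; one six-membered non-aromatic ring with 2 hetero atoms) in place of a group of 10 heavy atoms (6 carbon, 2 nitrogen, 2 sulfur; one six-membered non-aromatic ring with 2 hetero atoms), on a saturated chain carbon bound to a carbonyl carbon. The sulfur-bearing group leaves, and 4-ethylpiperazin-1-yl enters on a saturated chain carbon bound to a carbonyl carbon.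

Among the measured compounds shown here, only one measured step bears on this change, and only indirectly. That step is a 6.4-fold higher number from compound 1 to compound 2 (0.81 log units; beyond the scatter), a modest change beyond the scatter, and it came from 6-methoxy-1,2,3,4-tetrahydroquinolin-1-yl in place of 4-methylpiperazin-1-yl on a thiocarbonyl carbon. For the measured compounds named here, it shows that altering this group can move the number in this assay, but no measured step tests the loss of the thiocarbonyl carbon itself. A modest rise, meaning weaker inhibition, therefore seems the likeliest outcome, though with wide uncertainty. The expected step is a 2.3-fold higher number from compound 1 to compound 3 (0.37 log units; beyond the scatter). For compound 3 the estimated value is 3000 nM, with an expected range from 700 nM to 12000 nM.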

Compound 3, half-maximal inhibitory concentration: > 20000 nM
Compound 3: only a limit was reported; the forecaster's own chance of this, stated with the estimate: 8%; middle value at least 6.6-fold (0.82 log units) away from the limit.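

This change takes away the thiocarbonyl carbon and both sulfur atoms and puts 4-ethylpiperazin-1-yl on the saturated chain carbon bound to a carbonyl carbon, and the result is an at least 15-fold higher number from compound 1 to compound 3 (1.19 log units; beyond the scatter), which means much weaker inhibition in this assay. The earlier step, a 6.4-fold higher number from compound 1 to compound 2 (0.81 log units; beyond the scatter), replaced only the group on the thiocarbonyl carbon and cost less, so the new result shows that this larger change to the side chain can take inhibition further down than that swap did. The value for compound 3 is a limit and not a number: the limit of > 20000 nM in this assay, at which 1 of the 3 values shown sits.

Compound 3 differs from compound 1 both in the loss of the sulfur-bearing link and in carrying an ethyl group where compound 1 has a methyl group on the piperazine ring, and the compounds shown cannot say which of these two differences accounts for the loss. Placing 4-ethylpiperazin-1-yl on the thiocarbonyl carbon would test the ethyl group alone, while placing 4-methylpiperazin-1-yl or a morpholin-4-yl group on the saturated chain carbon would test the loss of the link.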